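Tert-Butyl in Place of Acetyl: What Compound 4 Might Show

The compounds below may be only part of what the source reports. "The series", "measured", "known", "first", "only" and "open" are said of these compounds alone.

In a functional assay on L5178Y cells (Mus musculus) for cytotoxicity, read by MTT assay (on this read-out lower numbers stand for stronger inhibition and higher numbers for weaker inhibition), compound 2 `CC(=O)c1ccc(OCCCCN2CCN(c3ccccn3)CC2)cc1` gives 63.7 nM. Compound 1 `CC(=O)c1ccc(OCCCCN2CCN(c3ncccn3)CC2)cc1` gives only a limit, > 100 nM. Compound 3 `CC(=O)c1ccc(OCCCN2CCN(c3ccncc3)CC2)cc1` likewise gives only a limit, > 100 nM. For the measured compounds named here, compound 2 thus holds the only number among the three, the other two sitting at the limit of > 100 nM in this assay, at which 2 of the 3 values shown sit. Going by the values given here, the one step between measured compounds, an at least 1.5-fold lower number from compound 1 to compound 2 (0.19 log units; that floor lies within the scatter), touches the ring nitrogen and not the aromatic carbon changed here. Compound 4 `CC(C)(C)c1ccc(OCCCCN2CCN(c3ccccn3)CC2)cc1` differs from compound 2 by tert-butyl in place of acetyl on an aromatic carbon. Among the compounds with values here, no measured step bears on this change; only a modest shift is expected, in no set direction. The estimate for compound 4 is 70 nM, between 30 nM and 200 nM, an expected step of a 1.1-fold higher number from compound 2 to compound 4 (0.04 log units; within the scatter).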

Compound 4, half-maximal inhibitory concentration: 15.1 nM
The estimate for compound 4 lay 4.6-fold (0.67 log units) above the measured number; measured number below the stated range.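

In this assay, the group on this aromatic carbon proves to matter, with tert-butyl in place of acetyl giving a 4.2-fold lower number from compound 2 to compound 4 (0.63 log units; beyond the scatter). For the compounds shown here, the earlier step touched only the ring on the amine nitrogen, so this is the first measured change at this place, and it shows that the carbonyl of the acetyl is not needed for a low number here. Few numbers are available for comparison: the limit of > 100 nM in this assay, at which 2 of the 4 values shown sit.

As far as these compounds go, whether a smaller alkyl group such as methyl, or an amine or a carboxylic acid, would behave like tert-butyl at this place remains open. Also open, from the compounds shown here alone, is whether the same change would lower the number with the pyrimidin-2-yl ring of compound 1.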